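The source may report more compounds than this note shows. Statements on the series, on what has been measured and on what is new or still open speak of the compounds shown alone.

In a functional assay on HeLa cells (Homo sapiens) for antiproliferative activity, read by cell counting, with a stated time of 4 days (on this read-out lower numbers stand for stronger inhibition and higher numbers for weaker inhibition), every result so far is a limit of the assay, not a number. Compound 1 `CCOC(=O)CN(Cc1ccc(F)cc1)c1ccc2c(c1)OC(C)(COc1ccc(C#N)cc1)CN2C` gives a limit of > 100000 nM. Compound 2 `CCOC(=O)CN(Cc1cc(F)cc(F)c1)c1ccc2c(c1)OC(C)(COc1ccc(C#N)cc1)CN2C` gives a limit of > 100000 nM. Compound 3 `CCOC(=O)C(=O)N(Cc1ccccc1)c1ccc2c(c1)OC(C)(CO)CN2C` also gives only a limit, > 100000 nM. Compound 4 `CN1CC(C)(CO)Oc2cc(N(Cc3ccccc3)C(=O)C(=O)O)ccc21` differs from compound 3 by one change, hydrogen in place of ethyl on an oxygen next to a carbonyl group, turning ethoxycarbonyl into carboxy: hydrogen in place of ethyl on an oxygen next to a carbonyl group. Among the measured compounds shown here, the only measured step, a step that the two limits leave unreadable from compound 1 to compound 2, has no readable size and involves a different change. No step beyond the scatter is expected in this assay because the limit of > 100000 nM in this assay, at which 3 of the 3 values shown sit, is all that compound 3 offers. The expected step is a number no higher from compound 3 to compound 4 (the limit leaves the size open). For compound 4 the estimated value is 100000 nM, with an expected range of 30000 nM to 300000 nM.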

Compound 4, half-maximal inhibitory concentration: > 100000 nM
Compound 4: only a limit was reported; the forecaster's own chance of this, stated with the estimate: 85%; the middle value lies on the limit itself.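

Compound 3 and compound 4 each give only a limit, so the change from ethoxycarbonyl to carboxy yields no readable step. The compounds shown leave open how strongly any of them acts in this assay, with every result so far a limit: the limit of > 100000 nM in this assay, at which 4 of the 4 values shown sit.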